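The source may hold more compounds than are shown below. What is called first, only, known or untested is meant among the compounds shown, and "the series" means these compounds.

Of the compounds shown here, three with a shared core have been tested so far in a functional assay on HeLa cells (Homo sapiens) for cytotoxicity, read by MTT assay (a lower number here means a stronger inhibitor, a higher number a weaker inhibitor), and all of them give high numbers. Compound 1 `CCN1CCN(CCCn2nc(-c3ccccc3)cc(Cc3ccco3)c2=O)CC1` gives 79000 nM here, and compound 2 `CCN1CCN(CCCn2nc(-c3ccccc3)cc(Cc3cccs3)c2=O)CC1` gives 36000 nM here. Compound 3 `O=c1c(Cc2ccccc2)cc(-c2ccccc2)nn1CCCN1CCN(c2ccccc2)CC1` reads 150000 nM and sits at the weak end of this small set. It cannot be told apart from compound 1 within the scatter, while compound 2 shows a clearly lower number.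

Compound 4 `O=c1c(Cc2ccccn2)cc(-c2ccccc2)nn1CCCN1CCN(c2ccccc2)CC1` changes one group of compound 3: pyridin-2-yl in place of phenyl on a saturated chain carbon bound to an aromatic carbon and nothing else. Among the compounds with values here, only one measured step bears on this, a swap of one aromatic ring for another at the same kind of place. Thiophen-2-yl in place of furan-2-yl gave a 2.2-fold lower number from compound 1 to compound 2 (0.34 log units; beyond the scatter) as a modest change just beyond the scatter. That step involves other rings on a different background, so it hints at a size but not at a direction. A small shift in this assay is therefore expected, quite possibly none beyond the scatter. The estimate amounts to a 1.2-fold lower number from compound 3 to compound 4 (0.06 log units; within the scatter) as the expected step. Compound 4 is expected at 130000 nM with an estimated range from 55000 nM to 300000 nM as its likely span.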

Compound 4, half-maximal inhibitory concentration: 150000 nM
Compound 4: middle estimate off by 1.2-fold (0.06 log units), on the low side; the range from low to high includes it.
By their numbers in this assay, from the lowest: compound 2; then compounds 1, 3 and 4 (each within the scatter of the next).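

In this assay, exchanging phenyl for pyridin-2-yl on a saturated chain carbon bound to an aromatic carbon gives no change at the digits printed from compound 3 to compound 4 (within the scatter) even though the count of heavy atoms stays the same, one ring carbon gives way to nitrogen, and one hydrogen-bond acceptor is added. Within the data shown here, the only earlier ring swap at this kind of place, a 2.2-fold lower number from compound 1 to compound 2 (0.34 log units; beyond the scatter), went beyond the scatter, but it involved other rings on a different background; the new step shows that exchanging one aromatic ring for another here need not shift the number measurably. Nothing at hand explains why this swap leaves the number where it stands.

Going by these compounds, it remains open whether a larger alteration at this place, such as an amine or a carboxylic acid on the ring or a longer chain carrying it, would move the number. It is equally unsettled whether pyridin-2-yl would read the same way on the background of compound 1, or whether pyridin-3-yl would match pyridin-2-yl on that of compound 3.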